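The source may report more compounds than this note shows. Statements on the series, on what has been measured and on what is new or still open speak of the compounds shown alone.

Measured so far:
Compound 1 `CCCCOC(=O)CCC(=O)N1CCN(CCCOc2cc3c(Nc4ccc(F)c(Cl)c4)ncnc3cc2OC)CC1`: in a functional assay on A549 cells (Homo sapiens) for cytotoxicity, read by MTT assay, with a stated time of 24 h, tested at 60 uM (a lower number here means a stronger effect, a higher number a weaker effect of the compound at the concentration tested), compound 1 gives 64.1%
Compound 2 `CCCCCCCCCCCCOC(=O)CCC(=O)N1CCN(CCCOc2cc3c(Nc4ccc(F)c(Cl)c4)ncnc3cc2OC)CC1`: in this assay compound 2 gives 2%

Compound 2 stands lowest of the two numbers; its nearest neighbour is compound 1, and the step of a number 62.1 percentage points lower from compound 1 to compound 2 (beyond the scatter) is beyond the scatter. Compound 3 `CCCCCCCCCCCCCCCCCCCOC(=O)CCC(=O)N1CCN(CCCOc2cc3c(Nc4ccc(F)c(Cl)c4)ncnc3cc2OC)CC1` is not yet measured in this assay. It differs from compound 2 by heptyl in place of hydrogen on a saturated chain carbon, ten or more bonds along the chain from an oxygen next to a carbonyl group. Among the measured compounds shown here, the only measured step that bears on this change is a number 62.1 percentage points lower from compound 1 to compound 2 (beyond the scatter), a large lowering from extending the same ester chain. Compound 2 already sits close to the floor of the read-out, so a further lowering of that size has no room to appear. The step of a number 1 percentage points higher from compound 2 to compound 3 (within the scatter) is therefore expected to be small, within the scatter or at most a slight lowering. Compound 3 is estimated at 3%, with a range from 0% to 15%. Whether a still longer chain turns the read-out back up is not shown by compounds 1 and 2.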

Compound 3, a percentage reported as activity, at one concentration (the size of the read-out at that concentration, not a potency): 89.3%
The estimate for compound 3 lay 86.3 percentage points below the measured number; the measured number lies above the stated range.
By their numbers in this assay, from the lowest: compound 2; then compound 1; then compound 3.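

Heptyl in place of hydrogen on a saturated chain carbon gives a number 87.3 percentage points higher from compound 2 to compound 3 (beyond the scatter) in this assay. This runs opposite to a number 62.1 percentage points lower from compound 1 to compound 2 (beyond the scatter), so lengthening this ester chain does not move the read-out in one direction across the three compounds, and compound 2 holds the lowest number among them. The data shown include nothing that accounts for this reversal.

Where the turn lies remains open, since chains of intermediate length between those of compound 2 and compound 3 would be needed to place it, and a longer chain would show whether the read-out stays high. Also open, on these data alone, is how an amine or a carboxylic acid carried on this chain would read.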